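Propyl in Place of Hydrogen: Expected Outcome for Compound 3

A few compounds are considered here, and "the series" means these few. Any claim that something is new, unique, unknown or untested is made for them only; others in the source may bear on it.

Compound 1 `CCCNNC(=O)c1cnc(N2CCN(Cc3c[nH]c4ccccc34)CC2)nc1` was measured in an assay on isolated protein for inhibition of histone deacetylase 4 (Homo sapiens); a higher number here means a weaker inhibitor, a lower number a stronger inhibitor. In this assay compound 1 gives > 20000 nM, which is a limit of the assay rather than a number. Compound 2 `CCCCCCNNC(=O)c1ccc(-c2ccc(CNC(C)=O)cc2)cc1` was measured too. In this assay compound 2 gives > 20000 nM, again a limit. Both values share (the limit of > 20000 nM in this assay, at which 2 of the 2 values shown sit). Compound 3 `CCCCCCNNC(=O)c1cnc(N2CCN(Cc3c[nH]c4ccccc34)CC2)nc1` differs from compound 1 by propyl in place of hydrogen on a saturated chain carbon, three bonds along the chain from an amine nitrogen. Within the data shown here, no measured step exists for this change, so no movement beyond the scatter is expected. The step that the limit leaves unreadable from compound 1 to compound 3 is expected to be small. Compound 3 is estimated at 30000 nM in this assay, between 10000 nM and 100000 nM.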

Compound 3, half-maximal inhibitory concentration: > 20000 nM
Compound 3: only a limit was reported; the forecaster's own chance of this, stated with the estimate: 85%; the middle value does not contradict the limit.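

No step from compound 1 to compound 3 can be read, since the value of each in this assay is only a limit: the limit of > 20000 nM in this assay, at which 3 of the 3 values shown sit.

The compounds shown leave open how strongly any of them inhibits, and whether propyl in place of hydrogen changes that.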